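Chloro scan on the benzyloxy amide series

The compounds below may be only part of what the source reports. "The series", "measured", "known", "first", "only" and "open" are said of these compounds alone.

Measured:
compound 1 `Cc1ccc(-c2nn(-c3ccccc3)cc2C(=O)NOCc2ccccc2)cc1` — 40800 nM
compound 2 `Cc1ccc(-c2nn(-c3ccccc3)cc2C(=O)NOCc2ccccc2Cl)cc1` — 38700 nM
compound 3 `COc1ccc(-c2nn(-c3ccccc3)cc2C(=O)NOCc2ccccc2Cl)cc1` — 586000 nM

In an ADME assay on HEK-293T cells (Homo sapiens) for antiproliferative activity, read by MTT assay, with a stated time of 48 h, in the presence of a further agent that is not named here (a higher number here means that more compound is tolerated, a lower number that less compound is tolerated), compound 1 gives 40800 nM. Adding chloro in place of hydrogen on an aromatic carbon gives a 1.1-fold lower number from compound 1 to compound 2 (0.02 log units; within the scatter). Swapping the methyl for methoxy gives a 15-fold higher number from compound 2 to compound 3 (1.18 log units; beyond the scatter), so compound 3 stands highest of the three; the difference between the core of compound 3 and the core of compound 1 is not broken down here.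

Compound 4 `COc1ccc(-c2nn(-c3ccccc3)cc2C(=O)NOCc2ccc(Cl)cc2Cl)cc1` carries chloro in place of hydrogen on an aromatic carbon. This is the same kind of change as from compound 1 to compound 2, but the place differs: there the chloro entered ortho to a large group; here it enters meta to a chloro group and para to a large group. Because a 1.1-fold lower number from compound 1 to compound 2 (0.02 log units; within the scatter) was small, a similarly small step a 1.2-fold lower number from compound 3 to compound 4 (0.07 log units; within the scatter) is expected in this assay. Compound 4 is therefore estimated at 500000 nM, between 200000 nM and 1300000 nM.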

Compound 4, half-maximal cytotoxic concentration: 545000 nM
Compound 4: middle estimate off by 1.1-fold (0.04 log units), on the low side; low and high end bracket the measured number.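

In this assay, adding the chloro gives a 1.1-fold lower number from compound 3 to compound 4 (0.03 log units; within the scatter), and this step matches the earlier one on the other core: the same change on two cores in this assay, a 1.1-fold lower number (0.02 log units; within the scatter) from compound 1 to compound 2 and a 1.1-fold lower number (0.03 log units; within the scatter) from compound 3 to compound 4, 1.0-fold (0.01 log units) apart, within the scatter of two such steps. Across these two pairs, the chloro change carries from one core to the other with no visible shift in this read-out. Among the compounds shown here, this does not establish a rule for the series: only two pairs are compared, and the chloro enters at a different place on the benzyl group in each.

Still open, as far as these compounds go, is whether the step from methyl to methoxy repeats with the 2,4-dichlorobenzyl group. Also open, from the compounds shown here alone, is whether an amine or a carboxylic acid in place of the chloro would leave the number similarly unchanged.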